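The source may report more compounds than this note shows. Statements on the series, on what has been measured and on what is new or still open speak of the compounds shown alone.

Compound 1: `O=[N+]([O-])c1cc(-c2nnc(SCc3ccccc3)n2Cc2ccccc2)cc([N+](=O)[O-])c1` — > 30000 nM
Compound 2: `CSc1nnc(-c2cc([N+](=O)[O-])cc([N+](=O)[O-])c2)n1Cc1ccccc1` — > 30000 nM

Of the compounds shown here, two sharing one core have been tested in an ADME assay on HepG2 cells (Homo sapiens) for cytotoxicity, with a stated time of 48 h; a lower number here means a stronger inhibitor, a higher number a weaker inhibitor. In this assay compound 1 gives > 30000 nM, which is a limit of the assay rather than a measured number. Compound 2 gives > 30000 nM, likewise a limit. The step that the two limits leave unreadable from compound 1 to compound 2 is unreadable for that reason; both results sit at the limit of > 30000 nM in this assay, at which 2 of the 2 values shown sit. Compound 2 thus stands at the limit, with no number of its own.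

Compound 3, `CCCSc1nnc(-c2cc([N+](=O)[O-])cc([N+](=O)[O-])c2)n1Cc1ccccc1`, differs from compound 2 by ethyl in place of hydrogen on a saturated chain carbon bound to a sulfur. For the measured compounds named here, only the step from compound 1 to compound 2 bears on this change, as it too alters the group on the saturated chain carbon bound to a sulfur, and its size is not readable. The expected step that the limit leaves unreadable from compound 2 to compound 3 is none beyond the scatter. Compound 3 is estimated at 40000 nM, with a range from 10000 nM to 150000 nM.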

Compound 3, half-maximal inhibitory concentration: > 30000 nM
Compound 3 gave a limit, no number; the forecaster's own chance of this, stated with the estimate: 85%; the middle value is on the limit's open side.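

For the compounds shown here, compound 3 gives > 30000 nM in this assay and this is again a limit, so no step among compound 1, compound 2 and compound 3 can be read. The compounds shown leave open whether in this assay phenyl, hydrogen or ethyl on a saturated chain carbon bound to a sulfur makes any difference.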